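A few compounds are considered here, and "the series" means these few. Any claim that something is new, unique, unknown or untested is made for them only; others in the source may bear on it.

Measured compounds:
- compound 1 `O=[N+]([O-])c1cc2c(OCCC3CCCCN3)c(-c3cccc(Cl)c3)c(O)nc2cc1Cl` — 40 nM
- compound 2 `Cc1cc(C)cc(-c2c(O)nc3cc(Cl)c(NC(=O)Nc4cccnc4)cc3c2OCCC2CCCCN2)c1` — 20 nM
- compound 3 `Cc1cc(C)cc(-c2c(O)nc3cc(Cl)c(NC(=O)Nc4ccccn4)cc3c2OCCC2CCCCN2)c1` — 15 nM

In a functional assay on cells (Pituitary gland cell) for antagonist activity at Gonadotropin-releasing hormone receptor (Rattus norvegicus) (a lower number here means a stronger inhibitor, a higher number a weaker inhibitor), compound 1 gives the highest of the three numbers. Its gap to compound 2 lies within the scatter; its gap to compound 3 lies beyond it. Among the compounds with values here, the one single-point step among the measured pairs is a 1.3-fold lower number from compound 2 to compound 3 (0.12 log units; within the scatter), a change at the urea end of the molecule, remote from the aryl group, and it lies within the scatter.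

Compound 4 `O=[N+]([O-])c1cc2c(OCCC3CCCCN3)c(-c3cc(Cl)cc(Cl)c3)c(O)nc2cc1Cl` differs from compound 1 by chloro in place of hydrogen on an aromatic carbon. Within the data shown here, no measured pair isolates this change. Compounds 2 and 3 carry a differently substituted aryl group at the same position, but they also differ from compound 1 at the other end of the shared core, so their values cannot be read as a test of the second chloro alone. The step from compound 2 to compound 3 concerns a different site and gives no guidance here.

With nothing directly comparable, the expectation for the step is a 1.4-fold lower number from compound 1 to compound 4 (0.15 log units; within the scatter), a change not clearly beyond the scatter in either direction. Compound 4 is therefore estimated at 28 nM, with a range from 9 nM to 90 nM.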

Compound 4, half-maximal inhibitory concentration: 24 nM
For compound 4 the middle estimate is 1.2-fold (0.07 log units) above the measured one; the measured number falls inside the stated range.
By their numbers in this assay, from the lowest: compounds 3, 2, 4 and 1 (each within the scatter of the next, the first and the last beyond it).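

Within the data shown here, the change from 3-chlorophenyl to 3,5-dichlorophenyl, read here for the first time on an otherwise unchanged structure in this assay, gives a 1.7-fold lower number from compound 1 to compound 4 (0.22 log units; within the scatter) as its one direct reading. Among these compounds, this aromatic carbon of the aryl group therefore accepts a second chloro on the core of compound 1 with no change beyond the usual scatter, and the single pair shows no clear gain or loss from the added atom. No measurement on hand offers an explanation for the size of this step, so the pair stands as an observation only.

From the compounds shown here alone, whether this tolerance extends to other groups remains open: a fluoro, a methoxy, a nitrile or a trifluoromethyl at this aromatic carbon could each be read against compound 1 as a single change, as could phenyl without any chloro, which would also test the first chloro. It is also open whether the second chloro gives a similar step with a urea in place of the nitro group, since no pair among the compounds shown isolates the change on that background.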